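Hydrogen for fluoro on the amide-side ring: tolerance of compound 4

The source may report more compounds than this note shows. Statements on the series, on what has been measured and on what is new or still open speak of the compounds shown alone.

Measured compounds:
compound 1 `CC(C)n1ncc2c(C(=O)Nc3cccc(S(N)(=O)=O)c3)cc(-c3cccs3)nc21`: 25000 nM
compound 2 `CC(C)n1ncc2c(C(=O)Nc3ccc(F)cc3)cc(-c3cccs3)nc21`: a limit of the assay, > 200000 nM
compound 3 `CC(C)n1ncc2c(C(=O)Nc3cc(C(N)=O)ccc3F)cc(-c3cccs3)nc21`: 25000 nM

In an ADME assay on LLC-MK2 cells (Macaca mulatta) for cytotoxicity, read by spectrophotometry and crystal violet staining, with a stated time of 4 days (a lower number here means that less compound is tolerated, a higher number that more compound is tolerated), compound 3 stands level with compound 1 at the digits shown, and the step of no change at the digits printed from compound 1 to compound 3 (within the scatter) is within the scatter. The value of compound 2 is a limit of the assay and not a number. Against that limit, the step of an at least 8.0-fold higher number from compound 1 to compound 2 (0.90 log units; beyond the scatter) and the step of an at least 8.0-fold lower number from compound 2 to compound 3 (0.90 log units; beyond the scatter) are both beyond the scatter, which matches the single limit described by the limit of > 200000 nM in this assay, at which 1 of the 3 values shown sits.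

Compound 4 `CC(C)n1ncc2c(C(=O)Nc3cccc(C(N)=O)c3)cc(-c3cccs3)nc21` differs from compound 3 by hydrogen in place of fluoro on an aromatic carbon. For the measured compounds named here, no measured step removes a fluoro on its own. Going by the values given here, the only step touching compound 3 that did not end at a limit, the step from compound 1 to compound 3, swapped the whole ring bearing the fluoro and stayed within the scatter. On that basis the account expects no step beyond the scatter, a 1.2-fold higher number from compound 3 to compound 4 (0.08 log units; within the scatter), in this assay. Compound 4 is therefore estimated at 30000 nM in this assay, within a range from 12000 nM to 80000 nM.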

Compound 4, half-maximal cytotoxic concentration: 25000 nM
Estimate against measurement, compound 4: 1.2-fold (0.08 log units) above, within the range that was stated.
By their numbers in this assay, from the lowest: compounds 1, 3 and 4 (each within the scatter of the next). At a limit, above all of these: compound 2.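

In this assay, for the compounds shown here, the fluoro on the 5-carbamoyl-2-fluorophenyl ring is exchanged on its own for the first time, and hydrogen in its place gives no change at the digits printed from compound 3 to compound 4 (within the scatter). Carbamoyl in place of sulfamoyl on an aromatic carbon, also a change in one place, gives no change at the digits printed from compound 1 to compound 4 (within the scatter), so the earlier ring swap from compound 1 to compound 3 can now be read in two smaller parts, neither of which separates the compounds. The 3-carbamoylphenyl ring without the fluoro still gives an at least 8.0-fold lower number from compound 2 to compound 4 (0.90 log units; beyond the scatter), and the value of compound 2 is a limit of the assay and not a number: the limit of > 200000 nM in this assay, at which 1 of the 4 values shown sits.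

The compounds shown leave open whether an amine or a carboxylic acid in place of the carbamoyl group would stay with compounds 1, 3 and 4 or move toward the limit of compound 2. Also open, as far as these compounds go, is where an unsubstituted phenyl ring on the amide nitrogen would stand.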